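From Methyl to Pentyl on a Shared Core

A few compounds are considered here, and "the series" means these few. Any claim that something is new, unique, unknown or untested is made for them only; others in the source may bear on it.

In a functional assay on HeLa cells (Homo sapiens) for antiproliferative activity, read by sulforhodamine B assay, with a stated time of 48 h (on this read-out lower numbers stand for stronger inhibition of growth and higher numbers for weaker inhibition of growth), compound 1 (`O=C1COc2ccccc2N1CCCn1cc(-c2ccccc2)nn1`) gives 9000 nM and compound 2 (`Cc1ccc(-c2cn(CCCN3C(=O)COc4ccccc43)nn2)cc1`) gives 14300 nM. Among the measured compounds shown here, these two numbers lie within the scatter of each other, so compound 2 does not stand apart from the only other measured compound.

Compound 3 (`CCCCCc1ccc(-c2cn(CCCN3C(=O)COc4ccccc43)nn2)cc1`) keeps the core of compound 2 and alters a single group: butyl in place of hydrogen on a saturated chain carbon bound to an aromatic carbon. Put another way, the methyl of compound 2 becomes pentyl.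

For the measured compounds named here, only one measured step bears on this change, the methyl in place of hydrogen on an aromatic carbon, and it amounts to a 1.6-fold higher number from compound 1 to compound 2 (0.20 log units; within the scatter). Going by the values given here, that step gives no sign of a trend, and no measured compound carries a chain as long as pentyl. No shift beyond the scatter is therefore expected, although the uncertainty is wide. The expected step is a 1.2-fold lower number from compound 2 to compound 3 (0.08 log units; within the scatter). For compound 3, the estimated value is 12000 nM, with an expected range from 4000 nM to 36000 nM.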

Compound 3, concentration for 50% growth inhibition: > 100000 nM
Compound 3: a limit, no number; the forecaster's own chance of this, stated with the estimate: 10%; at least 8.3-fold (0.92 log units) between middle value and limit.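

In this assay compound 3 gives > 100000 nM, which is a limit of the assay and not a number. Methyl in place of hydrogen on an aromatic carbon gave only a 1.6-fold higher number from compound 1 to compound 2 (0.20 log units; within the scatter), but extending that methyl to pentyl gives an at least 6.9-fold higher number from compound 2 to compound 3 (0.84 log units; beyond the scatter), and the full pentyl in place of hydrogen gives an at least 11-fold higher number from compound 1 to compound 3 (1.04 log units; beyond the scatter). This place on the shared core is therefore sensitive to the chain it carries, a sensitivity that the methyl step alone did not reveal, although only two chains show it and both steps to compound 3 rest on a single limit: the limit of > 100000 nM in this assay, at which 1 of the 3 values shown sits.

The compounds shown leave open where between methyl and pentyl the shift sets in, a question that an ethyl, propyl or butyl chain at this place could answer. They also leave open whether chain length itself matters, or whether a branched group such as tert-butyl, or a pentyl chain ending in an amine or a carboxylic acid, would give a different result.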